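The source may report more compounds than this note shows. Statements on the series, on what has been measured and on what is new or still open speak of the compounds shown alone.

Of the compounds shown here, three of a shared core have been tested in an ADME assay on cells (Fibroblast, Homo sapiens) for cytotoxicity, with a stated time of 48 h; a lower number here means a stronger inhibitor, a higher number a weaker inhibitor. Compound 1 `O=[N+]([O-])c1ccc(CN2CCC(n3cc(CC(OCc4cc(-c5ccc(F)cc5)no4)c4ccc(Br)cc4)nn3)CC2)cc1` reaches only the assay limit, reported as > 25000 nM. Compound 2 `N#Cc1ccc(-c2cc(COC(Cc3cn(C4CCN(Cc5ccc([N+](=O)[O-])cc5)CC4)nn3)c3ccc(Br)cc3)on2)cc1`, which carries a cyano in place of fluoro on an aromatic carbon, likewise reaches only a limit, > 25000 nM. Among the compounds with values here, compound 3 `O=[N+]([O-])c1ccc(CN2CCC(n3cc(CC(OCc4cc(-c5cccc(F)c5)no4)c4ccc(Br)cc4)nn3)CC2)cc1` is the one compound with a number, giving 10000 nM in this assay. Both measured steps leading to it are readable: an at least 2.5-fold lower number from compound 1 to compound 3 (0.39 log units; beyond the scatter) and an at least 2.5-fold lower number from compound 2 to compound 3 (0.39 log units; beyond the scatter), whereas a step that the two limits leave unreadable from compound 1 to compound 2. Compound 3 thus stands alone, apart from the limit of > 25000 nM in this assay, at which 2 of the 3 values shown sit.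

Compound 4 `COc1ccccc1-c1cc(COC(Cc2cn(C3CCN(Cc4ccc([N+](=O)[O-])cc4)CC3)nn2)c2ccc(Br)cc2)on1`, not yet measured, differs from compound 3 by 2-methoxyphenyl in place of 3-fluorophenyl on an aromatic carbon. Within the data shown here, the steps that bear on this change are the two aryl replacements already described, each at least modest in size and each moving the number down toward compound 3. They show that exchanging this aryl group can shift the number beyond the scatter, but they give no reading for a methoxy group in this place. An at least modest step back up, or none beyond the scatter, is expected; the estimated step is a 1.6-fold higher number from compound 3 to compound 4 (0.20 log units; within the scatter). Compound 4 is therefore expected to give about 16000 nM, in the range 5000 nM to 40000 nM, with a fair chance that only a limit is reported.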

Compound 4, half-maximal inhibitory concentration: > 25000 nM
Compound 4 gave a limit, no number; the forecaster's own chance of this, stated with the estimate: 45%; at least 1.5-fold (0.19 log units) between middle value and limit.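

In this assay, the new result gives an at least 2.5-fold higher number from compound 3 to compound 4 (0.39 log units; beyond the scatter), so the number of compound 3 is now also lost on moving to a 2-methoxyphenyl group on this aromatic carbon next to the ring nitrogen, and not only to the two para-free names already seen, 4-fluorophenyl and 4-cyanophenyl. Every readable step at this place now ends at or leaves compound 3 with 3-fluorophenyl on the lower side, and no compound shown goes against this, while the steps joining compound 4 to compound 1 and compound 2 cannot be read. Compound 3 therefore stands further apart from the rest of the set: the limit of > 25000 nM in this assay, at which 3 of the 4 values shown sit.

The compounds shown leave open whether the methoxy group or its place on the phenyl ring accounts for this step, which a 2-fluorophenyl or a 3-methoxyphenyl group at the same carbon could separate. They also leave open whether a 3-chlorophenyl or a 3-aminophenyl group here would give a number like that of compound 3.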